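Trimethoxyphenyl azetidinones: aryl change at the ring carbon

This account rests on a few compounds, and the source may have more. Where it says the series, first, only, none or still open, it means among the compounds named here.

Measured compounds:
compound 1 `COc1cc(N2C(=O)[C@@H](Oc3ccccc3)[C@H]2c2ccc(Br)cc2)cc(OC)c1OC` 48000 nM
compound 2 `COc1cc(N2C(=O)[C@@H](Oc3ccccc3)[C@H]2c2ccc(SC)cc2)cc(OC)c1OC` 7700 nM
compound 3 `COc1ccc([C@@H]2[C@H](Oc3ccccc3)C(=O)N2c2cc(OC)c(OC)c(OC)c2)c(N)c1O` 19000 nM

In a functional assay on MCF7 cells (Homo sapiens) for antiproliferative activity, read by MTT assay, with stated times of 24 h and 72 h (a lower number here means a stronger inhibitor, a higher number a weaker inhibitor), compound 1 gives the highest of the three numbers; its nearest neighbour is compound 3, and compound 2 lies furthest from it. The step of a 6.2-fold lower number from compound 1 to compound 2 (0.79 log units; beyond the scatter) comes from the methylsulfanyl in place of bromo on an aromatic carbon. The step of a 2.5-fold lower number from compound 1 to compound 3 (0.40 log units; beyond the scatter) comes from exchanging the whole aryl group on the saturated ring carbon. Between these two, a 2.5-fold higher number from compound 2 to compound 3 (0.39 log units; beyond the scatter).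

Compound 4 `COc1cc(N2C(=O)[C@@H](Oc3ccccc3)[C@H]2c2cc(N)c(OC)c(O)c2)cc(OC)c1OC` has not been measured in this assay. It differs from compound 1 as follows: a group of 10 heavy atoms (7 carbon, 1 nitrogen, 2 oxygen; one six-membered aromatic ring of carbon only) in place of a group of 7 heavy atoms (6 carbon, 1 bromine; one six-membered aromatic ring of carbon only), on a saturated ring carbon. Among the compounds with values here, the group that enters has the same count of carbon, nitrogen and oxygen as the one that enters in compound 3, arranged differently on the aromatic ring. The step of a 2.5-fold lower number from compound 1 to compound 3 (0.40 log units; beyond the scatter) is therefore the one that bears most directly on this change; the step of a 6.2-fold lower number from compound 1 to compound 2 (0.79 log units; beyond the scatter) is a different kind of change and is only a loose guide. A modest lowering of the number, of about the size seen for compound 3, is expected, a 2.5-fold lower number from compound 1 to compound 4 (0.40 log units; beyond the scatter). Compound 4 is estimated at 19000 nM, with a range from 7000 nM to 50000 nM.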

Compound 4, half-maximal inhibitory concentration: 8800 nM
Beside the measured number, compound 4's estimate is 2.2-fold (0.33 log units) above it; low and high end bracket the measured number.
By their numbers in this assay, from the lowest: compounds 2 and 4 (each within the scatter of the next); then compound 3; then compound 1.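

Working notes on the aryl group on the saturated ring carbon, read in this assay: the arrangement of the substituents on this aromatic ring affects the result, since the entering groups of compound 3 and compound 4 have the same count of carbon, nitrogen and oxygen, yet the series shows a 2.2-fold lower number from compound 3 to compound 4 (0.33 log units; beyond the scatter) as a step beyond the scatter. Replacing the 4-bromophenyl with the arrangement in compound 4 gives a 5.5-fold lower number from compound 1 to compound 4 (0.74 log units; beyond the scatter), a larger step than the one seen with the arrangement in compound 3, so the earlier result did not set the limit of what this atom set can do at this position. The series also shows a 1.1-fold higher number from compound 2 to compound 4 (0.06 log units; within the scatter), which places the methylsulfanyl compound and compound 4 within the scatter of each other, and no measurement at hand explains either this match or the effect of the arrangement.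

It remains open whether the amine or the hydroxyl on this aromatic ring accounts for the step, as neither is shown alone with the methoxy or without it. Also open, from the compounds shown here alone, is how a carboxylic acid on this ring would compare, or an amine in place of the phenoxy group on the neighbouring ring atom.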